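Working notes: fluoro in place of nitro

A few compounds are considered here, and "the series" means these few. Any claim that something is new, unique, unknown or untested is made for them only; others in the source may bear on it.

Values in a functional assay on KB cells (Homo sapiens) for inhibition; on this read-out higher numbers stand for weaker inhibition and lower numbers for stronger inhibition:
- Compound 1 `Nc1nc2cc(Cl)c(Cl)cc2n1Cc1ccc(Cl)cc1` gives 45000 nM
- Compound 2 `COc1ccc(Cn2c(N)nc3cc(Cl)c(Cl)cc32)cc1` gives 45000 nM
- Compound 3 `Nc1nc2cc(Cl)c(Cl)cc2n1Cc1ccc([N+](=O)[O-])cc1` gives 35000 nM

Compound 3 stands at 35000 nM, within the scatter of the other two compounds, so these three values form no order. Compound 4 `Nc1nc2cc(Cl)c(Cl)cc2n1Cc1ccc(F)cc1` has not yet been measured in this assay. It carries fluoro in place of nitro on an aromatic carbon of a six-membered aromatic ring of carbon only, para to a large group: fluoro in place of nitro on an aromatic carbon.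

Among the compounds with values here, three measured steps bear on this change, all made at that same place on the shared core. They are no change at the digits printed from compound 1 to compound 2 (within the scatter), a 1.3-fold lower number from compound 1 to compound 3 (0.11 log units; within the scatter) and a 1.3-fold lower number from compound 2 to compound 3 (0.11 log units; within the scatter). Each lies within the scatter, and none of the three compounds goes against this flat picture. Within the data shown here, no measured compound carries fluoro, so the expectation is carried over from chloro, methoxy and nitro alone and remains untested for fluoro.

The estimated outcome is a 1.1-fold higher number from compound 3 to compound 4 (0.06 log units; within the scatter), which means no expected step beyond the scatter. For compound 4 the expected value is 40000 nM, with an estimated range from 20000 nM to 80000 nM.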

Compound 4, half-maximal inhibitory concentration: 70000 nM
Compound 4: the middle estimate sits 1.8-fold (0.24 log units) below what was measured; the range from low to high includes it.
By their numbers in this assay, from the lowest: compounds 3, 1, 2 and 4 (each within the scatter of the next).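

Fluoro extends the flat picture at this aromatic carbon in this assay: the three steps to it are a 2.0-fold higher number from compound 3 to compound 4 (0.30 log units; within the scatter), a 1.6-fold higher number from compound 2 to compound 4 (0.19 log units; within the scatter) and a 1.6-fold higher number from compound 1 to compound 4 (0.19 log units; within the scatter). The step from nitro to fluoro is the largest of the six steps now available among the four compounds, yet it still lies within the scatter, so chloro, methoxy, nitro and fluoro at this place form no order, and the change from the three-heavy-atom nitro to the single-atom fluoro brings no step beyond the scatter. No measured information on these compounds bears on this result, so the data offer no explanation for it.

It remains open whether any group at this place can produce a step beyond the scatter, since all four groups shown give values that lie within the scatter of their neighbours in the order. On these data alone, an amine, a carboxylic acid or a longer alkyl chain on this aromatic carbon would test that, and the effect of changes elsewhere on the shared core also remains open.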